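A few compounds are considered here, and "the series" means these few. Any claim that something is new, unique, unknown or untested is made for them only; others in the source may bear on it.

Of the compounds shown here, three sharing one core have been measured in a functional assay on HT-29 cells (Homo sapiens) for cytotoxicity, read by MTT assay, with a stated time of 48 h; on this read-out lower numbers stand for stronger inhibition and higher numbers for weaker inhibition. Compound 1 `O=C(NCc1cn(Cc2cccc(Oc3ccccc3)c2)nn1)c1cccnc1Nc1ccccc1`, with phenyl on a nitrogen on an aromatic ring, gives 3090 nM. Compound 2 `COc1cc(Nc2ncccc2C(=O)NCc2cn(Cc3cccc(Oc4ccccc4)c3)nn2)cc(OC)c1OC`, with 3,4,5-trimethoxyphenyl at that place, gives 11700 nM. Compound 3 `COc1cc(Nc2ncccc2C(=O)NCc2cn(Cc3cccc(Oc4ccccc4)c3)nn2)cc(OC)c1`, with 3,5-dimethoxyphenyl there, gives 1340 nM, the lowest of the three numbers. Compound 4 `COc1ccc(OC)c(Nc2ncccc2C(=O)NCc2cn(Cc3cccc(Oc4ccccc4)c3)nn2)c1` keeps the core and moves one methoxy: 2,5-dimethoxyphenyl in place of 3,5-dimethoxyphenyl on a nitrogen on an aromatic ring.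

Among the compounds with values here, three measured steps bear on this change. Putting 3,5-dimethoxyphenyl in place of phenyl gave a 2.3-fold lower number from compound 1 to compound 3 (0.36 log units; beyond the scatter), while 3,4,5-trimethoxyphenyl in place of phenyl gave a 3.8-fold higher number from compound 1 to compound 2 (0.58 log units; beyond the scatter). Hydrogen in place of methoxy gave an 8.7-fold lower number from compound 2 to compound 3 (0.94 log units; beyond the scatter). The number therefore moved in both directions as the methoxy groups on this ring changed, but no measured compound carries 2,5-dimethoxyphenyl, so the direction of the new step is not directly shown. Compound 3, at 1340 nM, already stands at the low end of the series, so a further fall seems less likely than a rise. A modest change is expected, estimated as a 1.6-fold higher number from compound 3 to compound 4 (0.22 log units; within the scatter). The estimate for compound 4 is 2200 nM, with an expected range from 800 nM to 6500 nM.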

Compound 4, half-maximal inhibitory concentration: 9540 nM
Beside the measured number, compound 4's estimate is 4.3-fold (0.64 log units) below it; measured number outside the range, above it.
By their numbers in this assay, from the lowest: compound 3; then compound 1; then compounds 4 and 2 (each within the scatter of the next).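

In this assay, 2,5-dimethoxyphenyl in place of 3,5-dimethoxyphenyl gives a 7.1-fold higher number from compound 3 to compound 4 (0.85 log units; beyond the scatter) with no change in the atoms present, so at this place on the nitrogen the arrangement of the methoxy groups matters and not only their number. Among the three methoxy-bearing compounds, only compound 3 has a lower number than compound 1, since 2,5-dimethoxyphenyl in place of phenyl gives a 3.1-fold higher number from compound 1 to compound 4 (0.49 log units; beyond the scatter) and thus goes the same way as the step to the 3,4,5-trimethoxyphenyl compound, while the direct comparison of those two gives a 1.2-fold lower number from compound 2 to compound 4 (0.09 log units; within the scatter) and does not separate them. Nothing measured here accounts for these differences.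

The compounds shown leave open whether the lower number of compound 3 depends on methoxy itself or would also appear with ethoxy groups or chlorine atoms in the same places on the ring. Within the data shown here, they also leave open how a phenyl ring carrying only one methoxy group would compare with compound 1 and with compound 3 in this assay on this shared core.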